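The source may report more compounds than this note shows. Statements on the series, on what has been measured and on what is new or still open speak of the compounds shown alone.

Working notes on the series, all read in a functional assay on KB cells (Homo sapiens) for antiproliferative activity, with a stated time of 72 h (a lower number here means a stronger inhibitor, a higher number a weaker inhibitor), as the single measure. Among the measured compounds shown here, compound 1 (`C=C[C@@H]1C[C@@H](Cc2ccc(OC)c(O)c2)[C@H]2C(=O)C=CC(=C)[C@H]21`) gives 1.59 nM and holds the lowest of the three numbers so far. Compound 2 (`C=C1C=CC(=O)[C@@H]2[C@H](Cc3ccc(OCOC)cc3)CC[C@H]12`) gives 208 nM and compound 3 (`C=C1C=CC(=O)[C@@H]2[C@H](Cc3ccccc3)CC[C@H]12`) gives 591 nM on the same read-out. Compound 4 (`C=C1C=CC(=O)[C@@H]2[C@H](Cc3ccc(OC)c(O)c3)CC[C@H]12`) keeps the aromatic part of compound 1 but has hydrogen in place of vinyl on a saturated ring carbon. For the measured compounds named here, the one measured step, a 2.8-fold higher number from compound 2 to compound 3 (0.45 log units; beyond the scatter), is modest and replaces methoxymethoxy with hydrogen on an aromatic carbon, so it does not touch the place of this change. Going by the values given here, no measured pair isolates the loss of vinyl. Compound 2 and compound 3 also lack vinyl, but they differ from compound 1 in the aromatic part too, so their much higher numbers mix both differences. A rise beyond the scatter is therefore expected, though a smaller one than the gap from compound 1 to compound 2, which gives 208 nM in this assay, would suggest. The estimated change is a 13-fold higher number from compound 1 to compound 4 (1.10 log units; beyond the scatter) in this assay on this reasoning. Compound 4 is expected at 20 nM, within an estimated range of 4 nM to 120 nM on this read-out.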

Compound 4, half-maximal inhibitory concentration: 4.94 nM
Estimate against measurement, compound 4: 4.0-fold (0.61 log units) above; the range from low to high includes it.
By their numbers in this assay, from the lowest: compound 1; then compound 4; then compound 2; then compound 3.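

In this assay, among the compounds shown here, hydrogen in place of vinyl on a saturated ring carbon gives a 3.1-fold higher number from compound 1 to compound 4 (0.49 log units; beyond the scatter), the first reading that isolates this change from any difference in the aromatic part. The step lies beyond the scatter but is modest, and without vinyl compound 4 still gives 4.94 nM, so vinyl is not needed for a single-digit nanomolar number when the aromatic part of compound 1 is kept. No measurement shown explains the size of this step, and nothing on hand bears on its cause.

The compounds shown carry only vinyl and hydrogen at this ring carbon, so what an ethyl group, a longer chain, an amine or a carboxylic acid would give there remains open. For the compounds shown here, it is also open whether vinyl would bring a step of similar size with the aromatic parts of compound 2 and compound 3, since the one pair that reads this change shares the aromatic part of compound 1.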